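The source may hold more compounds than are shown below. What is called first, only, known or untested is meant among the compounds shown, and "the series" means these compounds.

Compound 3 `CN(C)CCCOc1c(OCc2ccccc2)cc(O)c2c(=O)cc(-c3ccccc3)oc12` belongs to a small set in which a basic chain hangs from an oxygen on the shared core. In a functional assay on A549 cells (Homo sapiens) for cytotoxicity, read by MTT assay, with a stated time of 72 h (a higher number here means a weaker inhibitor, a lower number a stronger inhibitor), compound 3 gives 2910 nM, the second highest of three numbers. Its nearest neighbour is compound 1 `COc1c(OCCCCN2CCN(C)CC2)cc(O)c2c(=O)cc(-c3ccc(C)cc3)oc12`, which gives 3810 nM, a gap within the scatter; the furthest is compound 2 `COc1c(OCCCCN2CCN(C)CC2)cc(O)c2c(=O)cc(-c3cccc(F)c3)oc12`, which gives 2090 nM, also within the scatter.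

Compound 4 `CN1CCN(CCCCOc2c(OCc3ccccc3)cc(O)c3c(=O)cc(-c4ccccc4)oc23)CC1` differs from compound 3 in one place: (4-methylpiperazin-1-yl)methyl in place of dimethylamino on a saturated chain carbon, three bonds along the chain from an oxygen on an aromatic ring. Among the compounds with values here, no measured pair reports this exact change. Within the data shown here, the only single-place step recorded, a 1.8-fold lower number from compound 1 to compound 2 (0.26 log units; within the scatter), concerns the aryl ring and not the chain, so it does not bear on the change at hand. Compounds 1 and 2 do carry the 4-(4-methylpiperazin-1-yl)butyl chain that compound 4 receives, yet both differ from compound 4 elsewhere as well, so their values show only that such a chain sits among numbers close to that of compound 3.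

On these grounds he expects no step beyond the scatter, a 1.0-fold higher number from compound 3 to compound 4 (0.01 log units; within the scatter), in this assay. Compound 4 is therefore estimated at 3000 nM, within a range of 1200 nM to 7500 nM.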

Compound 4, half-maximal inhibitory concentration: 2910 nM
Estimate against measurement, compound 4: 1.0-fold (0.01 log units) above; low and high end bracket the measured number.
By their numbers in this assay, from the lowest: compounds 2, 3, 4 and 1 (each within the scatter of the next).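

Within the data shown here, putting the 4-(4-methylpiperazin-1-yl)butyl chain in place of the 3-(dimethylamino)propyl chain gives no change at the digits printed from compound 3 to compound 4 (within the scatter) in this assay, the first direct reading of this change, since compounds 1 and 2 differ from each other only on the aryl ring. With the rest of the structure held the same, this position accepts a chain that brings in a six-membered non-aromatic ring with 2 hetero atoms, and the number does not move beyond the scatter. Nothing measured here offers an account of this result.

A single pair cannot say whether the same holds when the 4-methylphenyl or the 3-fluorophenyl of compounds 1 and 2 replaces the plain phenyl ring of compound 3 and compound 4. The compounds shown also leave open how this position would read with a morpholine or a primary amine at the end of the chain, with a carboxylic acid there, or with a plain butyl chain carrying no amine at all.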